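Replacing a difluorophenyl group with a trifluoromethylphenyl group

The source may report more compounds than this note shows. Statements on the series, on what has been measured and on what is new or still open speak of the compounds shown alone.

Of the compounds shown here, three built on one shared core have been tested in a functional assay on HepG2 cells (Homo sapiens) for inhibition, read by MTT assay, with a stated time of 72 h; on this read-out higher numbers stand for weaker inhibition and lower numbers for stronger inhibition. Compound 1 `CN(C(=O)NC(=O)c1cccc(C(F)(F)F)c1)c1nc(C(F)(F)F)c(C(=O)N/N=C/c2ccccc2C(F)(F)F)s1` gives 10.4 ug/mL. Compound 3 `CN(C(=O)NC(=O)c1c(F)cccc1F)c1nc(C(F)(F)F)c(C(=O)N/N=C/c2ccccc2C(F)(F)F)s1` gives 26.1 ug/mL, which is the higher of the two plain numbers recorded. Compound 2 `CN(C(=O)NC(=O)c1ccc(C(F)(F)F)cc1)c1nc(C(F)(F)F)c(C(=O)N/N=C/c2ccc(C(F)(F)F)cc2)s1` reaches only (the limit of > 100 ug/mL in this assay, at which 1 of the 3 values shown sits), so its result of > 100 ug/mL is a limit of the assay and not a number.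

Among the measured compounds shown here, the one measured step that touches the group on the carbonyl carbon is a 2.5-fold higher number from compound 1 to compound 3 (0.40 log units; beyond the scatter), a modest weakening when a 2,6-difluorophenyl replaced a 3-(trifluoromethyl)phenyl. Compound 4 `CN(C(=O)NC(=O)c1ccc(C(F)(F)F)cc1)c1nc(C(F)(F)F)c(C(=O)N/N=C/c2ccccc2C(F)(F)F)s1` is reached from compound 3 by the change (4-(trifluoromethyl)phenyl in place of 2,6-difluorophenyl on a carbonyl carbon). This puts back a trifluoromethylphenyl group, though with the trifluoromethyl at a different place on the ring than in compound 1. Compound 4 also carries the same 4-(trifluoromethyl)phenyl on that carbonyl as compound 2, while its other aryl group matches compounds 1 and 3. For the measured compounds named here, the only measured step therefore points to a small change, with the limit seen for compound 2 leaving room for a weaker result. Compound 4 is expected to give 40 ug/mL, within a range from 12 ug/mL to 150 ug/mL, which would mean a step of a 1.5-fold higher number from compound 3 to compound 4 (0.19 log units; within the scatter).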

Compound 4, half-maximal inhibitory concentration: 3.64 ug/mL
Estimate against measurement, compound 4: 11-fold (1.04 log units) above; the measured number lies below the stated range.
By their numbers in this assay, from the lowest: compound 4; then compound 1; then compound 3. At a limit, above all of these: compound 2.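

Moving the trifluoromethyl group around the phenyl ring on the carbonyl carbon matters more than the earlier pair suggested: the 4-(trifluoromethyl)phenyl of compound 4 gives a 2.9-fold lower number from compound 1 to compound 4 (0.46 log units; beyond the scatter) when it replaces the 3-(trifluoromethyl)phenyl, and a 7.2-fold lower number from compound 3 to compound 4 (0.86 log units; beyond the scatter) when it replaces the 2,6-difluorophenyl, so among these three groups it gives the strongest inhibition in this assay. Compound 2 carries that same group on the carbonyl carbon, yet its result is a limit of the assay and not a number: the limit of > 100 ug/mL in this assay, at which 1 of the 4 values shown sits. The 4-(trifluoromethyl)phenyl on the carbonyl carbon is therefore not enough alone, since putting 2-(trifluoromethyl)phenyl in place of 4-(trifluoromethyl)phenyl on the carbon with a double bond to nitrogen gives an at least 27-fold lower number from compound 2 to compound 4 (1.43 log units; beyond the scatter), the largest step in this set.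

The compounds shown leave open whether the group on the carbon with a double bond to nitrogen has the same weight when other groups sit on the carbonyl carbon, as this rests on a single pair. They also leave open how the carbonyl position responds to a phenyl ring bearing something other than fluorine, such as a methoxy group, an amine or a carboxylic acid.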